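The source may report more compounds than this note shows. Statements on the series, on what has been measured and on what is new or still open speak of the compounds shown alone.

Compound 3 `CC(C)c1cn([C@H]2C[C@@H]3OP(=O)(O)OC[C@H]3O2)c(=O)[nH]c1=O` gives, in a functional assay on Raji cells (Homo sapiens) (a higher number here means a weaker inhibitor, a lower number a stronger inhibitor), only a limit of the assay, > 500 ug/mL. Compound 1 `CCc1cn([C@H]2C[C@@H]3OP(=O)(O)OC[C@H]3O2)c(=O)[nH]c1=O` likewise reaches only a limit in this assay, > 500 ug/mL. Compound 2 `CCCCCCCCc1cn([C@H]2C[C@@H]3OP(=O)(O)OC[C@H]3O2)c(=O)[nH]c1=O` gives 184 ug/mL in this assay. Compound 4 `CCCCCc1cn([C@H]2C[C@@H]3OP(=O)(O)OC[C@H]3O2)c(=O)[nH]c1=O` differs from compound 3 by pentyl in place of isopropyl on an aromatic carbon. Within the data shown here, two measured steps bear on this change: an at least 2.7-fold higher number from compound 2 to compound 3 (0.43 log units; beyond the scatter), and an at least 2.7-fold lower number from compound 1 to compound 2 (0.43 log units; beyond the scatter). The comparison a step that the two limits leave unreadable from compound 1 to compound 3 adds nothing, because both values sit at the limit of > 500 ug/mL in this assay, at which 2 of the 3 values shown sit. Among the measured compounds, the longer chains went with the lower numbers, compound 2 alone giving a number rather than a limit. For compound 4 a modest lowering, an at least 1.6-fold lower number from compound 3 to compound 4 (0.22 log units; that floor lies within the scatter), is therefore expected, its exact size uncertain. Compound 4 is estimated at 300 ug/mL, between 120 ug/mL and 600 ug/mL.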

Compound 4, concentration for 50% inhibition: > 500 ug/mL
Compound 4: only a limit was reported (the forecaster's own chance of this, stated with the estimate: 35%); middle value at least 1.6-fold (0.22 log units) from the limit.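

Compound 4, with pentyl on the aromatic carbon, reaches only a limit in this assay and gives no number. Among these compounds, the one readable step is an at least 2.7-fold higher number from compound 2 to compound 4 (0.43 log units; beyond the scatter) and it places pentyl with ethyl and isopropyl at this position, not with octyl. The steps from compound 1 and from compound 3 to compound 4 cannot be read because both ends of each are limits: the limit of > 500 ug/mL in this assay, at which 3 of the 4 values shown sit.

The compounds shown leave open whether a hexyl or heptyl chain already gives a number. They also leave open whether a chain longer than octyl, or one ending in an amine or a carboxylic acid, would lower it further.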